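A Larger Group on the Small Ring: Expected Tolerance

The source may hold more compounds than are shown below. What is called first, only, known or untested is meant among the compounds shown, and "the series" means these compounds.

Three measured compounds share one core: compound 1 `COc1nc2ccccc2cc1/C=C/c1noc(-c2ccc(C)cc2)n1`, compound 2 `COc1nc2ccccc2cc1/C=C/c1noc(-c2ccc(F)cc2)n1` and compound 3 `COc1nc2ccccc2cc1/C=C/c1noc(C)n1`. In an ADME assay on HepG2 cells (Homo sapiens) for cytotoxicity, read by sulforhodamine B assay, with a stated time of 48 h (a lower number here means that less compound is tolerated, a higher number that more compound is tolerated), compound 1 gives > 230000 nM, which is a limit of the assay rather than a number. Compound 2 likewise gives only a limit, > 230000 nM. Compound 3 gives > 300000 nM, again a limit. Because every value sits at a limit, as the limit of > 230000 nM in this assay, at which 2 of the 3 values shown sit, and the limit of > 300000 nM in this assay, at which 1 of the 3 values shown sits, show, the steps a step that the two limits leave unreadable from compound 1 to compound 2, a step that the two limits leave unreadable from compound 1 to compound 3 and a step that the two limits leave unreadable from compound 2 to compound 3 cannot be read in size, so compound 3 stands at the higher of the two limits and no more can be said about its place.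

Compound 4 `COc1nc2ccccc2cc1/C=C/c1noc(/C=C/c2ccccc2)n1` differs from compound 3 by 2-phenylethenyl in place of methyl on an aromatic carbon. For the measured compounds named here, none of the measured steps gives a readable size that bears on this change, so no direction is expected with confidence in this assay. The step from compound 3 to compound 4 is estimated as an at least 1.5-fold lower number from compound 3 to compound 4 (0.17 log units; that floor lies within the scatter). Compound 4 is expected to give about 200000 nM, within a range of 50000 nM to 400000 nM, most likely reported again as a limit.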

Compound 4, half-maximal cytotoxic concentration: > 225000 nM
Compound 4: no number, only a limit (the forecaster's own chance of this, stated with the estimate: 65%); middle value at least 1.1-fold (0.05 log units) away from the limit.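

Compound 4 also gives only a limit in this assay, as do compound 1, compound 2 and compound 3, so none of the steps to compound 4 can be read in size. The compounds shown leave open what concentration any of the four tolerates, and whether changing the group alters it.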